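The source may hold more compounds than are shown below. What is called first, only, known or untested is meant among the compounds shown, and "the series" means these compounds.

In a functional assay on HeLa cells (Homo sapiens) for inhibition, read by sulforhodamine B assay (a lower number here means a stronger inhibitor, a higher number a weaker inhibitor), three compounds sharing one core have been measured so far, and they differ in the group on an amine nitrogen. Compound 1 `O=C1C=C(NCc2ccccc2)C(=O)c2c1nc1n2[C@H]2OC[C@@H](O)[C@H]2OC1` reads > 8000 nM, which is a limit of the assay and not a number. Compound 2 `O=C1C=C(Nc2ccccc2F)C(=O)c2c1nc1n2[C@H]2OC[C@@H](O)[C@H]2OC1` gives 5120 nM, and compound 3 `CCc1ccc(NC2=CC(=O)c3nc4n(c3C2=O)[C@H]2OC[C@@H](O)[C@H]2OC4)cc1` gives 3990 nM. These last two values stand within the scatter of each other, so compound 3 sits level with compound 2 on the numbers available.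

The next compound, compound 4 `O=C1C=C(Nc2cccc(F)c2)C(=O)c2c1nc1n2[C@H]2OC[C@@H](O)[C@H]2OC1`, carries 3-fluorophenyl in place of 4-ethylphenyl on an amine nitrogen. Like compound 2, it has a fluorine on the ring. Among the measured compounds shown here, three measured steps bear on this change. Two of them start from the limit and give only floors within the scatter: an at least 1.5-fold lower number from compound 1 to compound 2 (0.19 log units; that floor lies within the scatter) and an at least 2.0-fold lower number from compound 1 to compound 3 (0.30 log units; that floor lies within the scatter). For the measured compounds named here, because a 1.3-fold lower number from compound 2 to compound 3 (0.11 log units; within the scatter) is the only step with a number at both ends, and it lies within the scatter, no step beyond the scatter is expected in this assay. The expected step is a 1.1-fold higher number from compound 3 to compound 4 (0.05 log units; within the scatter), and its direction is not firmly estimated. For compound 4 the estimated value is 4500 nM, with an expected range from 2200 nM to 8000 nM.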

Compound 4, half-maximal inhibitory concentration: 6440 nM
The estimate for compound 4 lay 1.4-fold (0.16 log units) below the measured number, within the range that was stated.
By their numbers in this assay, from the lowest: compounds 3, 2 and 4 (each within the scatter of the next). At a limit, above all of these: compound 1.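

In this assay, the fluorine-bearing pair adds a 1.3-fold higher number from compound 2 to compound 4 (0.10 log units; within the scatter), and the change from the ethyl-bearing ring adds a 1.6-fold higher number from compound 3 to compound 4 (0.21 log units; within the scatter), so neither the 3-fluorophenyl group nor its difference from the other two aryl groups on this amine nitrogen separates the compounds beyond the scatter. With compound 4 there are now three aryl compounds with numbers, and every step among them stays within the scatter, so this position has so far shown no measurable preference among these three groups. Compound 1 reads > 8000 nM, which is a limit and not a number: the limit of > 8000 nM in this assay, at which 1 of the 4 values shown sits.

The comparison with benzyl yields only a floor, an at least 1.2-fold lower number from compound 1 to compound 4 (0.09 log units; that floor lies within the scatter), and so leaves the standing of benzyl against 3-fluorophenyl unsettled. The compounds shown leave open whether an amine or a carboxylic acid on the phenyl ring, or a longer chain in place of the ethyl, would move the number beyond the scatter, and every compound here carries the shared core unchanged, so what a change to the core would do also remains open.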